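Restoring the amine hydrogen in a sulfonamide series

The source may report more compounds than this note shows. Statements on the series, on what has been measured and on what is new or still open speak of the compounds shown alone.

Compound 1 `O=S(=O)(NCCCNCc1ccc(Cl)c(Cl)c1)c1cc(C(F)(F)F)cc(C(F)(F)F)c1` and compound 2 `O=S(=O)(NCCCNCc1ccc(C(F)(F)F)cc1)c1cc(C(F)(F)F)cc(C(F)(F)F)c1` carry the same chain and differ only in the aryl group of the benzylamine. In a functional assay on MIA PaCa-2 cells (Homo sapiens) for inhibition, read by MTT assay, with a stated time of 72 h (a higher number here means a weaker inhibitor of growth, a lower number a stronger inhibitor of growth), compound 1 gives 2700 nM and compound 2 gives 2500 nM, a step of a 1.1-fold lower number from compound 1 to compound 2 (0.03 log units; within the scatter). Compound 3 `CN(CCCNS(=O)(=O)c1cc(C(F)(F)F)cc(C(F)(F)F)c1)Cc1ccccc1` stands highest of the three, giving 33000 nM in this assay, and the step of a 12-fold higher number from compound 1 to compound 3 (1.09 log units; beyond the scatter) is large. Compound 4 `COc1ccccc1CNCCCNS(=O)(=O)c1cc(C(F)(F)F)cc(C(F)(F)F)c1` differs from compound 3 by (2-methoxybenzyl)amino in place of benzyl(methyl)amino on a saturated chain carbon, three bonds along the chain from a sulfonamide nitrogen, which brings back the amine hydrogen that compound 3 lacks and swaps the ring substituent. Since a 1.1-fold lower number from compound 1 to compound 2 (0.03 log units; within the scatter) shows the ring substituent mattered little, the large loss in a 12-fold higher number from compound 1 to compound 3 (1.09 log units; beyond the scatter) is attributed mostly to the amine methyl, so a large fall is expected: a 9.4-fold lower number from compound 3 to compound 4 (0.97 log units; beyond the scatter). Compound 4 is estimated at 3500 nM, within 1200 nM to 12000 nM.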

Compound 4, concentration for 50% growth inhibition: 3100 nM
Compound 4: the middle estimate sits 1.1-fold (0.05 log units) above what was measured; the measured number falls inside the stated range.
By their numbers in this assay, from the lowest: compounds 2, 1 and 4 (each within the scatter of the next); then compound 3.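

In this assay, (2-methoxybenzyl)amino in place of benzyl(methyl)amino gives a large step (an 11-fold lower number from compound 3 to compound 4 (1.03 log units; beyond the scatter)). A third aryl group now stands level with the other two (a 1.2-fold higher number from compound 2 to compound 4 (0.09 log units; within the scatter); a 1.1-fold higher number from compound 1 to compound 4 (0.06 log units; within the scatter)), so the three compounds with an amine hydrogen sit together, apart from compound 3 with its amine methyl. Nothing measured here gives a reason for this gap. Going by these compounds, the ring and the methyl change together between compound 3 and compound 4, so their shares stay unknown. Unsubstituted benzylamino on the same chain would separate them.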